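Chloropyridine to Fluoromethylpyridine: Expected Lipophilicity of Compound 4

The source may hold more compounds than are shown below. What is called first, only, known or untested is meant among the compounds shown, and "the series" means these compounds.

Compound 1, `Cc1ccc(Oc2cc3c(cn2)nc(COc2cccc(C(=O)O)c2)n3C)cc1`: 1
Compound 2, `Cn1c(COc2cccc(C(=O)O)c2)nc2cnc(Oc3ccc4c(c3)CCC4)cc21`: 1.6
Compound 3, `Cn1c(COc2cccc(C(=O)O)c2)nc2ccc(Oc3cccc(Cl)n3)cc21`: 1.2

All three share the same core and differ only in the group attached to an oxygen on an aromatic ring. They were measured in a physicochemical assay for lipophilicity, read by LC-MS, in phosphate buffer, measured as octanol-water partition, with a stated time of 30 min, at pH 7.4, tested at 200 mM; a higher number here means a more lipophilic compound, a lower number a more polar compound. Among the three numbers compound 3 stands second highest, with 1.2; compound 1 lies nearest, within the usual scatter, and compound 2 lies furthest, above compound 3 by more than the scatter.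

Compound 4, `Cc1cnc(Oc2ccc3nc(COc4cccc(C(=O)O)c4)n(C)c3c2)c(F)c1`, is not yet measured. It differs from compound 3 in one place: 3-fluoro-5-methylpyridin-2-yl in place of 6-chloropyridin-2-yl on an oxygen on an aromatic ring. Among the measured compounds shown here, the only measured step that changes the group on that same oxygen is a number 0.60 log units higher from compound 1 to compound 2 (beyond the scatter), a modest rise for a different swap. For the measured compounds named here, no measured pair exchanges one pyridinyl ring for another, nor a chlorine for a fluorine and a methyl, so the evidence is indirect. Going by the values given here, the heavy-atom count grows by one, and the single step seen for a swap in this place was modest. Compound 4 is therefore expected near 1.3, between 0.9 and 1.7. The expected step is a number 0.10 log units higher from compound 3 to compound 4 (within the scatter), which would fall within the scatter.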

Compound 4, distribution coefficient: 1.1
For compound 4 the middle estimate is 0.20 log units above the measured one; the range from low to high includes it.
By their numbers in this assay, from the lowest: compounds 1, 4 and 3 (each within the scatter of the next); then compound 2.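

Exchanging one pyridinyl group for another on this oxygen, with 8 heavy atoms entering where 7 leave, gives the first step of this kind in this assay (a number 0.10 log units lower from compound 3 to compound 4 (within the scatter)), so compound 3 and compound 4 cannot be told apart by this measurement. Among the compounds shown here, the only earlier step at this place, 2,3-dihydro-1H-inden-5-yl in place of 4-methylphenyl (a number 0.60 log units higher from compound 1 to compound 2 (beyond the scatter)), lay beyond the scatter, whereas this one shows that a chlorine can leave and a fluorine and a methyl can enter on a pyridinyl ring with no readable shift in the number. Nothing available gives a reason for this result.

From the compounds shown here alone, the chlorine, the fluorine and the methyl all change in this one step, so what each contributes alone stays open, and a pyridinyl ring carrying only the fluorine or only the methyl would be needed to separate them. Also open, going by these compounds, is how the number would respond to a quite different group on this oxygen, such as a piperidinyl ring or a longer chain like hexyl.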